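Aryl variation on the ring nitrogen of the shared core

The compounds below may be only part of what the source reports. "The series", "measured", "known", "first", "only" and "open" are said of these compounds alone.

Measured compounds:
- compound 2, `O=C(Nc1ccc(Oc2ccnc3[nH]ccc23)c(F)c1)c1cn(-c2ccccc2)c2ccccc2c1=O`: 760 nM
- compound 3, `O=C(Nc1ccc(Oc2ccnc3[nH]ccc23)c(F)c1)c1cn(-c2ccc(Br)cc2F)c2ccccc2c1=O`: 2200 nM
- compound 1, `Cn1ccc2c(Oc3ccc(NC(=O)c4cn(-c5ccc(C(F)(F)F)cc5Cl)c5ccccc5c4=O)cc3F)ccnc21`: "not determined" (no result reported)

The series is followed in a functional assay on HepG2 cells (Homo sapiens) for inhibition, read by MTT assay, with a stated time of 72 h; a lower number here means a stronger inhibitor, a higher number a weaker inhibitor. Compound 2 gives 760 nM in this assay, and compound 3 gives 2200 nM. Compound 1 has "not determined" (no result reported) in this assay. Among the compounds with values here, the one single-point step, a 2.9-fold higher number from compound 2 to compound 3 (0.46 log units; beyond the scatter), is modest yet beyond the scatter. Compound 3 thus stands with the highest of the two numbers; its nearest neighbour is compound 2.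

Compound 4, `O=C(Nc1ccc(Oc2ccnc3[nH]ccc23)c(F)c1)c1cn(-c2ccc(C(F)(F)F)cc2Cl)c2ccccc2c1=O`, carries the change (2-chloro-4-(trifluoromethyl)phenyl in place of 4-bromo-2-fluorophenyl on an aromatic nitrogen). Within the data shown here, no measured step exchanges one substituted phenyl for another; the only step at this position, a 2.9-fold higher number from compound 2 to compound 3 (0.46 log units; beyond the scatter), runs from an unsubstituted phenyl to a substituted one and is therefore only an indirect guide. With both compound 3 and compound 4 bearing a substituted phenyl, the expectation is a step in this assay near the scatter, direction open, written as a 1.1-fold lower number from compound 3 to compound 4 (0.04 log units; within the scatter).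

Compound 4 is accordingly estimated at 2000 nM in this assay, with a range from 700 nM to 6000 nM.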

Compound 4, half-maximal inhibitory concentration: 1840 nM
Beside the measured number, compound 4's estimate is 1.1-fold (0.04 log units) above it; low and high end bracket the measured number.
By their numbers in this assay, from the lowest: compound 2; then compounds 4 and 3 (each within the scatter of the next).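

In this assay, exchanging one substituted phenyl for another on the aromatic nitrogen gives a 1.2-fold lower number from compound 3 to compound 4 (0.08 log units; within the scatter), so 2-chloro-4-(trifluoromethyl)phenyl and 4-bromo-2-fluorophenyl cannot be told apart at this position, although the entering group has 11 heavy atoms and the leaving group 8. The second substituted phenyl also departs from the plain phenyl, with a 2.4-fold higher number from compound 2 to compound 4 (0.38 log units; beyond the scatter), a modest step in the same direction as a 2.9-fold higher number from compound 2 to compound 3 (0.46 log units; beyond the scatter), and neither of the two substituted phenyls with a number in this assay goes against this direction. Nothing measured on hand accounts for these steps.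

The compounds shown leave open what a single substituent on the phenyl does by itself, since both substituted examples carry two changes to the ring at once. They also leave open whether a phenyl carrying an amine or a carboxylic acid, or a methyl group or longer alkyl chain in place of the phenyl on the aromatic nitrogen, would give a number at or under that of compound 2 in this assay.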